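Boronic acid series: sulfonyl aryl swap on two cores

This account rests on a few compounds, and the source may have more. Where it says the series, first, only, none or still open, it means among the compounds named here.

Compound 1 `CC(C)C[C@H](NC(=O)CSc1cc(NS(=O)(=O)c2ccc(Cl)cc2)c2ccccc2c1O)B(O)O` and compound 2 `CC(C)C[C@H](NC(=O)CSc1cc(NS(=O)(=O)c2cccs2)c2ccccc2c1O)B(O)O` stand on one core; compound 3 `CC(C)C[C@H](NC(=O)CCSc1cc(NS(=O)(=O)c2ccc(Cl)cc2)c2ccccc2c1O)B(O)O` and compound 4 `CC(C)C[C@H](NC(=O)CCSc1cc(NS(=O)(=O)c2cccs2)c2ccccc2c1O)B(O)O` stand on a second. In a functional assay on A549 cells (Homo sapiens) for antiproliferative activity, read by sulforhodamine B assay, with a stated time of 72 h (a higher number here means a weaker inhibitor, a lower number a stronger inhibitor), compound 1 gives 6900 nM, compound 2 gives 7540 nM and compound 3 gives 8100 nM. The two cores differ as a group of 12 heavy atoms (7 carbon, 1 boron, 1 nitrogen, 3 oxygen; no ring) in place of a group of 11 heavy atoms (6 carbon, 1 boron, 1 nitrogen, 3 oxygen; no ring), on a saturated chain carbon bound to a sulfur, with the step of a 1.2-fold higher number from compound 1 to compound 3 (0.07 log units; within the scatter). The change from compound 1 to compound 2 is thiophen-2-yl in place of 4-chlorophenyl on a sulfonyl sulfur, and it made a step of a 1.1-fold higher number from compound 1 to compound 2 (0.04 log units; within the scatter). The change from compound 3 to compound 4 is thiophen-2-yl in place of 4-chlorophenyl on a sulfonyl sulfur, at the same place, so it is the same change. For compound 4 a step of a 1.1-fold higher number from compound 3 to compound 4 (0.04 log units; within the scatter) in this assay is expected, resting on the flat step a 1.1-fold higher number from compound 1 to compound 2 (0.04 log units; within the scatter) seen for this change. In this assay compound 4 is therefore estimated at 8900 nM, most likely between 5000 nM and 16000 nM.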

Compound 4, half-maximal inhibitory concentration: 5930 nM
Beside the measured number, compound 4's estimate is 1.5-fold (0.18 log units) above it, and the stated range covers the measured number.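

In this assay, thiophen-2-yl in place of 4-chlorophenyl on a sulfonyl sulfur gives a 1.4-fold lower number from compound 3 to compound 4 (0.14 log units; within the scatter), so this step is flat on the second core, as it was on the first. The two steps do not differ: the same change on two cores in this assay, a 1.1-fold higher number (0.04 log units; within the scatter) from compound 1 to compound 2 and a 1.4-fold lower number (0.14 log units; within the scatter) from compound 3 to compound 4, 1.5-fold (0.17 log units) apart, within the scatter of two such steps. This shows that a flat step carries between these two cores, but since neither step leaves the scatter, it shows no real effect of the change on either core and does not test whether a larger effect would carry.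

Still open, as far as these compounds go, is whether a pyridyl ring or a carboxylic acid in this place would give an equally flat step. Also open, from the compounds shown here alone, is whether a longer chain on the sulfur would leave the change flat.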